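The source may report more compounds than this note shows. Statements on the series, on what has been measured and on what is new or still open speak of the compounds shown alone.

Working notes on the series. The shared core carries a methoxyphenyl group, and the chain on the other side of it is varied. Compound 1 `COc1ccc(-c2cc3ccccc3nc2C=O)cc1` is the aldehyde. In a functional assay on A549 cells (Homo sapiens) for antiproliferative activity, read by XTT assay, with a stated time of 72 h (on this read-out higher numbers stand for weaker inhibition and lower numbers for stronger inhibition), compound 1 gives > 10000 nM, which is a limit of the assay and not a number. Compound 2 `COc1ccc(-c2cc3ccccc3nc2/C=C/C(=O)c2ccc(O)cc2)cc1` extends the aldehyde into an enone bearing a 4-hydroxyphenyl group, and in this assay compound 2 gives 7440 nM. Compound 3 `COc1ccc(-c2cc3ccccc3nc2/C=C/C(=O)c2ccc(OC)cc2OC)cc1` carries a 2,4-dimethoxyphenyl group in the same place and in this assay compound 3 gives 7990 nM. Of the two numbers, compound 2 holds the lower one, but the step of a 1.1-fold higher number from compound 2 to compound 3 (0.03 log units; within the scatter) is within the scatter, so the two compounds are not separated; the remaining value is the limit of compound 1.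

Compound 4 `COc1ccc(-c2cc3ccccc3nc2/C=C/C(=O)c2ccc[nH]2)cc1` differs from compound 2 only at the carbonyl carbon: 1H-pyrrol-2-yl in place of 4-hydroxyphenyl on a carbonyl carbon. Within the data shown here, the one measured step bearing on this position, a 1.1-fold higher number from compound 2 to compound 3 (0.03 log units; within the scatter), shows that swapping the aryl group on the carbonyl carbon did not move the number beyond the scatter. On that evidence no step beyond the scatter is expected from compound 2 to compound 4 in this assay; the expected step is a 1.0-fold higher number from compound 2 to compound 4 (0.00 log units; within the scatter). Compound 4 is therefore estimated at 7500 nM, with a range from 2500 nM to 20000 nM.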

Compound 4, half-maximal inhibitory concentration: > 10000 nM
Compound 4: a limit, no number (the forecaster's own chance of this, stated with the estimate: 30%); middle value at least 1.3-fold (0.12 log units) away from the limit.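

In this assay compound 4 gives a limit and not a number, so a change on the carbonyl carbon now reaches the end of the readable range, where this series already has another compound: the limit of > 10000 nM in this assay, at which 2 of the 4 values shown sit. With 1H-pyrrol-2-yl in place of the six-membered aryl groups, the readable steps are an at least 1.3-fold higher number from compound 2 to compound 4 (0.12 log units; that floor lies within the scatter) and an at least 1.2-fold higher number from compound 3 to compound 4 (0.09 log units; that floor lies within the scatter); both floors lie within the scatter, so compound 4 is not yet separated from either compound, although its true distance from them may be greater than these floors. Unlike a 1.1-fold higher number from compound 2 to compound 3 (0.03 log units; within the scatter), which has a number at both ends and stays within the scatter, these steps have an open upper end, and the step that joins the two limits, from the aldehyde compound 1 to compound 4, cannot be read.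

On these data alone, how far the true value of compound 4 lies past its limit remains open, so the size of the change at this position is unknown. Also open, as far as these compounds go, is how a 4-aminophenyl or a 4-carboxyphenyl group on the carbonyl carbon would read in this assay.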